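The source may report more compounds than this note shows. Statements on the series, on what has been measured and on what is new or still open speak of the compounds shown alone.

Of the compounds shown here, three have been tested in a functional assay on HeLa cells (Homo sapiens) for antiproliferative activity, read by XTT assay, with a stated time of 72 h; a higher number here means a weaker inhibitor, a lower number a stronger inhibitor. Compound 3 `C=C(C)CCC[C@]1(C)C2=CCC[C@](C)(C[C@H](O)C3=CC(=O)OC3O)[C@H]2CC[C@H]1C` gives 3800 nM. Compound 1 `C=C(C)CCC[C@]1(C)C2=CCC[C@](C)(C[C@H](OC(C)=O)C3=CC(=O)OC3O)[C@H]2CC[C@H]1C`, in this assay, gives 2600 nM; the step of a 1.5-fold lower number from compound 3 to compound 1 (0.16 log units; within the scatter) came from the change (acetyl in place of hydrogen on an oxygen on a saturated carbon). Compound 2 `C=C(C)CC[C@]1(C)C2=CCC[C@](C)(C[C@@H](O)C3=CC(=O)OC3O)[C@H]2CC[C@H]1C` gives 5400 nM in this assay; the difference between the core of compound 2 and the core of compound 3 is not broken down here.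

Compound 4 `C=C(C)CC[C@]1(C)C2=CCC[C@](C)(C[C@@H](OC(C)=O)C3=CC(=O)OC3O)[C@H]2CC[C@H]1C` is not yet measured. It differs from compound 2 by acetyl in place of hydrogen on an oxygen on a saturated carbon, the same change that turned compound 3 into compound 1, at a place described in identical words. Because compound 3 to compound 1 showed a 1.5-fold lower number from compound 3 to compound 1 (0.16 log units; within the scatter), a step of similar size is expected, a 1.4-fold lower number from compound 2 to compound 4 (0.15 log units; within the scatter). Compound 4 is therefore estimated at 3800 nM, expected to fall between 1800 nM and 8000 nM.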

Compound 4, half-maximal inhibitory concentration: 6700 nM
Estimate against measurement, compound 4: 1.8-fold (0.25 log units) below; low and high end bracket the measured number.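

In this assay, the change from hydroxy to acetoxy gives a 1.2-fold higher number from compound 2 to compound 4 (0.09 log units; within the scatter). Set beside the earlier step, this one does not differ from it by more than the scatter of two such steps allows: the same change on two cores in this assay, a 1.5-fold lower number (0.16 log units; within the scatter) from compound 3 to compound 1 and a 1.2-fold higher number (0.09 log units; within the scatter) from compound 2 to compound 4, 1.8-fold (0.26 log units) apart, within the scatter of two such steps. The change therefore carries across these two cores with no step beyond the scatter on either, but steps this small cannot show a real effect of the change or a real difference between the cores, and two cores say nothing about any other core.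

The compounds shown leave open whether a longer acyl chain, such as butanoyl, would give a larger step. They also leave open what an amine in place of the hydroxy would do on either core.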